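The source may report more compounds than this note shows. Statements on the series, on what has been measured and on what is new or still open speak of the compounds shown alone.

Measured compounds:
compound 1 `Brc1ccc(-c2nnc(Nc3cccc(Br)c3)s2)cc1` gives 17300 nM
compound 2 `Clc1ccc(Nc2nnc(-c3ccc(Br)cc3)s2)cc1Cl` gives 7160 nM
compound 3 `Clc1ccc(Nc2nnc(-c3ccccc3Cl)s2)cc1Cl` gives 2160 nM

In an assay on isolated protein for inhibition of beta-glucuronidase (Bos taurus), read by spectrophotometry, with a stated time of 30 min (a lower number here means a stronger inhibitor, a higher number a weaker inhibitor), compound 1 gives the highest of the three numbers. Compound 2 comes nearest to it, and compound 3, the lowest, lies furthest away; both differences are beyond the scatter. Within the data shown here, the only single-point step among the measured compounds is a 3.3-fold lower number from compound 2 to compound 3 (0.52 log units; beyond the scatter), and it concerns the aryl ring attached to the shared core of compound 2, not the ring bearing the amine.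

Compound 4 `Brc1ccc(-c2nnc(Nc3ccccc3)s2)cc1` differs from compound 1 by hydrogen in place of bromo on an aromatic carbon, the change sitting on an aromatic carbon of a six-membered aromatic ring of carbon only, meta to a large group. Among the measured compounds shown here, no measured step touches this position, so the step from compound 2 to compound 3 offers no direct guide. For the measured compounds named here, compound 1 and compound 2 differ on the amine-bearing ring, with compound 2 showing the lower number, but they are not a single-point pair, and no step is counted for them.

With nothing measured on this ring position, the expectation for compound 4 is a step of a 1.3-fold higher number from compound 1 to compound 4 (0.10 log units; within the scatter), that is, no change beyond the scatter or a slight rise. Compound 4 is therefore estimated at 22000 nM, between 8000 nM and 60000 nM.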

Compound 4, half-maximal inhibitory concentration: 40200 nM
Estimate against measurement, compound 4: 1.8-fold (0.26 log units) below; measured number inside the range.
By their numbers in this assay, from the lowest: compound 3; then compound 2; then compound 1; then compound 4.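

The bromo on the amine-bearing ring, meta to a large group, proves to matter in this assay: with hydrogen in place of bromo, the result is a 2.3-fold higher number from compound 1 to compound 4 (0.37 log units; beyond the scatter) and so a modest loss. Among these compounds, this is the first single-point reading on this ring, since the earlier step concerned only the aryl ring on the other side of the shared core. The bromo therefore goes with the lower number of this pair, but nothing available explains the difference.

The compounds shown leave open whether a chloro, a methoxy or an amine in this place would give a lower or a higher number than bromo. They also leave open whether the same exchange would bring a similar step with a 2-chlorophenyl group on the shared core.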